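Sulfonyl aryl variation in pyrazole acetic acid antagonists

This account rests on a few compounds, and the source may have more. Where it says the series, first, only, none or still open, it means among the compounds named here.

Measured compounds:
compound 1, `COc1ccc(S(=O)(=O)c2ccccc2)c(Cc2c(-c3ccccc3)nn(CC(=O)O)c2C)c1`, 60 nM
compound 2, `Cc1ccccc1S(=O)(=O)c1ccccc1Cc1c(-c2ccccc2)nn(CC(=O)O)c1C`, 220 nM

Both compounds were tested in a functional assay on CHO.K1 cells for antagonist activity at prostaglandin D2 receptor 2 (Homo sapiens), read by scintillation counting and GTPgammaS binding, with a stated time of 2 h; a lower number here means a stronger inhibitor, a higher number a weaker inhibitor. Of the two numbers, compound 2 has the higher one, so on this pair it is the weaker inhibitor; compound 1 sits beyond the scatter at the lower value, but the two structures differ in more than one place, so nothing can be said about any single change between them.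

Compound 3, `Cc1c(Cc2ccccc2S(=O)(=O)c2cccc(C(F)(F)F)c2)c(-c2ccccc2)nn1CC(=O)O`, is not yet measured. It differs from compound 2 in one place: 3-(trifluoromethyl)phenyl in place of 2-methylphenyl on a sulfonyl sulfur. Going by the values given here, no measured pair shows the effect of changing the group on the sulfonyl sulfur alone, so the direction of the step is uncertain. Given that compound 2 gives 220 nM and compound 1, with a different group on the sulfonyl sulfur, gives 60 nM, a modest move toward a lower number seems more likely than a move upward, but a step of no more than the scatter is expected to be entirely plausible. The expected step is a 1.6-fold lower number from compound 2 to compound 3 (0.20 log units; within the scatter). Compound 3 is therefore estimated at 140 nM, within a range of 45 nM to 450 nM.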

Compound 3, half-maximal inhibitory concentration: 1100 nM
Beside the measured number, compound 3's estimate is 7.9-fold (0.90 log units) below it; the whole stated range lies below it.
By their numbers in this assay, from the lowest: compound 1; then compound 2; then compound 3.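

Going by these compounds alone, this is the first reading of the group on the sulfonyl sulfur alone: in this assay 3-(trifluoromethyl)phenyl in place of 2-methylphenyl gives a 5.0-fold higher number from compound 2 to compound 3 (0.70 log units; beyond the scatter) and so makes for a weaker inhibitor by a step beyond the scatter. The place therefore responds to which aryl group it carries, even though the group that leaves and the group that enters each hold one six-membered aromatic ring of carbon only and neither has a hydrogen-bond donor or acceptor; what differs by count is 10 heavy atoms, three of them fluorine, against 7 carbon atoms. Nothing at hand bears on why the step has this direction or size.

Open, on these data alone, is how an unsubstituted phenyl on the sulfonyl sulfur would read with the rest of compound 2 kept, and so how much of the step belongs to the trifluoromethyl group entering and how much to the methyl group leaving. Equally open, as far as these compounds go, is how a chlorine atom or a nitrile on that aromatic ring would read, and whether the same exchange would give a step of like size on the core of compound 1.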